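Fluoro to Chloro: Expected Stability of Compound 3

The compounds below may be only part of what the source reports. "The series", "measured", "known", "first", "only" and "open" are said of these compounds alone.

Compound 2 `CC(=O)Nc1cc(-c2ccc(OC[C@@H](N)CC(C)C)c(F)c2)ccn1` was examined in an ADME assay on microsomes from liver (Mus musculus) for metabolic stability, read by LC-MS, using NADPH, with a stated time of 10 min, tested at 0.5 uM (a higher number here means that more of the compound is left, a lower number that less of the compound is left), where compound 2 gives 79%. Among the compounds with values here, of the two compounds measured so far, compound 2 stands lowest; its nearest neighbour is compound 1 `CC(=O)Nc1cc(-c2cc(F)c(OC[C@@H](N)CC(C)C)c(F)c2)ccn1`, and in this assay compound 1 gives 90%. Within the data shown here, the single measured step between them, a number 11 percentage points lower from compound 1 to compound 2 (beyond the scatter), is the only step that bears on the change considered here, and it is of modest size.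

Compound 3 `CC(=O)Nc1cc(-c2ccc(OC[C@@H](N)CC(C)C)c(Cl)c2)ccn1` has not yet been measured in this assay. (chloro in place of fluoro on an aromatic carbon). Among the measured compounds shown here, no measured pair compares chloro with fluoro, so the measured step offers only a loose guide. Since a number 11 percentage points lower from compound 1 to compound 2 (beyond the scatter) showed that taking a fluoro away lowered the number, a chloro in its place is expected to move the number in this assay only a little, most likely not beyond the scatter, with a slight lean downward.

For compound 3 the expected value is 72%, within a range from 55% to 88%. This amounts to an expected step of a number 7 percentage points lower from compound 2 to compound 3 (within the scatter).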

Compound 3, percent of the compound remaining: 86%
Estimate against measurement, compound 3: 14 percentage points below, and the stated range covers the measured number.
By their numbers in this assay, from the lowest: compounds 2, 3 and 1 (each within the scatter of the next, the first and the last beyond it).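

In this assay, placing a chloro instead of a fluoro on this aromatic carbon, ortho to the (2-amino-4-methylpentyl)oxy group, gives a number 7 percentage points higher from compound 2 to compound 3 (within the scatter), so this single swap does not separate the two compounds. The earlier step, a number 11 percentage points lower from compound 1 to compound 2 (beyond the scatter), concerned the loss of the second fluoro that compound 1 carries, and it said nothing about changing the halogen that compound 2 and compound 3 hold at this position; the new pair shows that, on the shared core, either halogen can sit here with no difference beyond the usual scatter of this measurement. No supporting measurement is available that could explain why these two compounds read alike.

The compounds shown leave open how a methyl, a methoxy or a nitrile on this same aromatic carbon would read in this assay, and so whether the result extends beyond these two halogens. They also leave open whether a chloro here would read the same with the second fluoro of compound 1 present on the ring.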